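A few compounds are considered here, and "the series" means these few. Any claim that something is new, unique, unknown or untested is made for them only; others in the source may bear on it.

Of the compounds shown here, three that share one core have been tested in an unclassified assay for pharmacokinetics, read by NMR, tested at 2 mg/mL; a higher number here means that the compound lasts longer, a lower number that the compound disappears faster. Compound 1 (`COc1n[nH]c2ncc(NC(=O)c3c(F)ccc(/N=N\c4ccccc4)c3F)cc12`) gives > 10 h, which is a limit and not a number. Compound 2 (`COc1n[nH]c2ncc(NC(=O)c3c(F)ccc(/N=N\c4ccccc4F)c3F)cc12`) gives > 20 h, also a limit. Compound 3 (`COc1n[nH]c2ncc(NC(=O)c3c(F)ccc(/N=N\c4ccc(C)cc4)c3F)cc12`) gives > 20 h, again a limit, so where it stands is known only from that bound.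

Compound 4 (`COc1n[nH]c2ncc(NC(=O)c3c(F)ccc(/N=N\c4ccc(F)cc4)c3F)cc12`) departs from compound 3 in one place: fluoro in place of methyl on an aromatic carbon. This is fluoro in place of methyl on an aromatic carbon, para to a large group, so that 4-methylphenyl becomes 4-fluorophenyl.

Among the measured compounds shown here, three measured steps bear on this change. For the measured compounds named here, the first is a step that the two limits leave unreadable from compound 1 to compound 2, with fluoro in place of hydrogen on an aromatic carbon. The second is a step that the two limits leave unreadable from compound 1 to compound 3, with methyl in place of hydrogen on an aromatic carbon. The third is a step that the two limits leave unreadable from compound 2 to compound 3, with 4-methylphenyl in place of 2-fluorophenyl. None of them offers a size or a direction to carry over. The expectation of no step beyond the scatter rests only on (the limit of > 20 h in this assay, at which 2 of the 3 values shown sit), and compound 3 is one of those two values. The estimated step is a step that the limit leaves unreadable from compound 3 to compound 4, with no direction favoured. For compound 4 the expected half-life is 25 h, with an estimated range of 12 h to 60 h, and a report as a limit alone is expected to be likely.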

Compound 4, half-life: > 20 h
Compound 4 ended at the assay's limit (the forecaster's own chance of this, stated with the estimate: 75%); the middle value is on the limit's open side.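

In this assay, among the compounds shown here, compound 1, compound 2, compound 3 and compound 4 are all reported only as limits, so no step from any of them to compound 4 can be read. The compounds shown leave open how long each one actually lasts, and whether 4-fluorophenyl and 4-methylphenyl differ at all.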